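Replacing the carbamoyl group of compound 3

The source may report more compounds than this note shows. Statements on the series, on what has been measured and on what is new or still open speak of the compounds shown alone.

Compound 3 `CCOc1ccc(Br)cc1-c1cc(Nc2ccc(C(N)=O)cc2)nc(N)n1` gives 750 nM in an assay on Sf9 cells for inhibition of 1-acyl-sn-glycerol-3-phosphate acyltransferase beta (Homo sapiens) (on this read-out lower numbers stand for stronger inhibition and higher numbers for weaker inhibition), the highest of the three numbers measured; compound 2 `CCOc1ccc(Br)cc1-c1cc(Nc2ccc(B(O)O)cc2)nc(N)n1` gives 91 nM and compound 1 `COc1ccc(Cl)cc1-c1cc(Nc2ccc(Cl)cc2)nc(N)n1` gives 54 nM. Going by the values given here, the one measured step at this position, an 8.2-fold higher number from compound 2 to compound 3 (0.92 log units; beyond the scatter), shows that exchanging the group on the aromatic carbon para to a large group can shift the number well beyond the scatter. Compound 4 `CCOc1ccc(Br)cc1-c1cc(Nc2ccc(C(=N)N)cc2)nc(N)n1` carries a group of 3 heavy atoms (1 carbon, 2 nitrogen; no ring) in place of a group of 3 heavy atoms (1 carbon, 1 nitrogen, 1 oxygen; no ring), on an aromatic carbon. Among the compounds with values here, no measured pair covers this particular exchange, so the direction rests only on the spread seen between compound 2 and compound 3, which argues against a large rise. The expected step is a 1.9-fold lower number from compound 3 to compound 4 (0.27 log units; within the scatter), at most a modest lowering. The estimate for compound 4 is 400 nM, range 120 nM to 1500 nM.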

Compound 4, half-maximal inhibitory concentration: > 5000 nM
Compound 4: no number, only a limit; the forecaster's own chance of this, stated with the estimate: 3%; at least 12-fold (1.09 log units) between middle value and limit.
By their numbers in this assay, from the lowest: compounds 1 and 2 (each within the scatter of the next); then compound 3. At a limit, above all of these: compound 4.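

In this assay compound 4 gives no number, only a limit: the limit of > 5000 nM in this assay, at which 1 of the 4 values shown sits.

The exchange of carbamoyl for the new group reads as an at least 6.6-fold higher number from compound 3 to compound 4 (0.82 log units; beyond the scatter), and the exchange of the group of compound 2 for it reads as an at least 54-fold higher number from compound 2 to compound 4 (1.73 log units; beyond the scatter). On the aromatic carbon para to a large group, heavy-atom count alone therefore does not set the number, since compound 2, compound 3 and compound 4 all carry groups of 3 heavy atoms.

As far as these compounds go, how far compound 4 lies beyond its limit stays open. Also open, from the compounds shown here alone, is where a carboxylic acid or a nitrile at this place would fall.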